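Lengthening the chain on compound 1 by one carbon

The compounds below may be only part of what the source reports. "The series", "measured", "known", "first", "only" and "open" are said of these compounds alone.

The measured compounds:
compound 1 `CCCCN1CCCN(c2nc3ccccc3n2CCOCC)CC1` — 8.4 nM
compound 2 `CCSCCn1c(N2CCN(C)CC2)nc2ccccc21` — 19 nM
compound 3 `CN1CCCN(c2nc3ccccc3n2CCOc2ccccc2)CC1` — 9.1 nM

In a functional assay on ileum for inhibition of histamine H1 receptor (Cavia porcellus) (a higher number here means a weaker inhibitor, a lower number a stronger inhibitor), compound 1 gives the lowest of the three numbers. Its number and that of compound 3 differ by an amount that lies within the scatter, so no order between those two can be read; compound 2 stands beyond the scatter above compound 1. Among the compounds with values here, no pair among the measured compounds differs in only one place, so no single-change step is available to guide the next compound.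

Compound 4 `CCCCCN1CCCN(c2nc3ccccc3n2CCOCC)CC1` is not yet measured. It differs from compound 1 by methyl in place of hydrogen on a saturated chain carbon, four bonds along the chain from an amine nitrogen in a ring. Within the data shown here, nothing among the measured compounds shows what such a lengthening does in this assay. The step is small in what it adds, and the expectation is that it changes the number little, with no step beyond the scatter in either direction. Compound 4 is therefore estimated at 10 nM, in the range 4 nM to 30 nM, which amounts to an expected step of a 1.2-fold higher number from compound 1 to compound 4 (0.08 log units; within the scatter).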

Compound 4, half-maximal inhibitory concentration: 7.4 nM
The estimate for compound 4 lay 1.4-fold (0.13 log units) above the measured number; the range from low to high includes it.
By their numbers in this assay, from the lowest: compounds 4, 1 and 3 (each within the scatter of the next); then compound 2.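

In this assay the lengthening gives a 1.1-fold lower number from compound 1 to compound 4 (0.06 log units; within the scatter) and stands within the scatter, so it supplies the first single-change step among these compounds. It shows that methyl in place of hydrogen on a saturated chain carbon, four bonds along the chain from an amine nitrogen in a ring, leaves the number without a readable change, though this rests on one step at one place. No measurement available here explains why the number holds at this position.

The compounds shown leave open whether a longer chain, a branched chain or a chain ending in a phenyl ring or a hydroxyl group would also hold the number at this place. They also leave open whether the same added carbon would read alike on a compound with a different group elsewhere in the molecule.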